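Replacing an aromatic group with a short branched chain

This account rests on a few compounds, and the source may have more. Where it says the series, first, only, none or still open, it means among the compounds named here.

Measured compounds:
- compound 1 `COc1cccc(CNCCCNc2ccnc3cc(Cc4ccccc4)ccc23)c1O` gives 23 10^-6 cm/s
- compound 2 `COc1cccc(CNCCCNc2ccnc3cc(Oc4ccc(F)cc4)ccc23)c1O` gives 317 10^-6 cm/s
- compound 3 `COc1cccc(CNCCCNc2ccnc3cc(-c4ccc(C(F)(F)F)cc4)ccc23)c1O` gives 237 10^-6 cm/s

These three compounds were run in an ADME assay for permeability, using PAMPA, with a stated time of 30 min, at pH 7.4; on this read-out lower numbers stand for lower permeability and higher numbers for higher permeability. Compound 3 stands second highest of the three; its number sits close to that of compound 2, since a 1.3-fold lower number from compound 2 to compound 3 (0.13 log units; within the scatter), while a 10-fold higher number from compound 1 to compound 3 (1.01 log units; beyond the scatter).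

Compound 4 `CCC(CC)c1ccc2c(NCCCNCc3cccc(OC)c3O)ccnc2c1` has not yet been measured. It differs from compound 3 in one place: pentan-3-yl in place of 4-(trifluoromethyl)phenyl on an aromatic carbon. Pentan-3-yl has no ring, unlike the group it replaces.

Going by the values given here, two measured steps bear on this change, both at the same aromatic carbon. a 14-fold higher number from compound 1 to compound 2 (1.14 log units; beyond the scatter), and a 10-fold higher number from compound 1 to compound 3 (1.01 log units; beyond the scatter); both show that the group at this position can move the number a great deal. Among the compounds with values here, no measured compound carries a chain without a ring there, so the direction is uncertain. A step below the two ring-bearing compounds is expected, with compound 3 as the starting point: a 2.0-fold lower number from compound 3 to compound 4 (0.30 log units; within the scatter) is the estimated change. For compound 4 the estimate in this assay is 120 10^-6 cm/s, with a range from 35 10^-6 cm/s to 300 10^-6 cm/s.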

Compound 4, apparent permeability: 23 10^-6 cm/s
Compound 4: middle estimate off by 5.2-fold (0.72 log units), on the high side; the whole stated range lies above it.
By their numbers in this assay, from the lowest: compounds 1 and 4 (each within the scatter of the next); then compounds 3 and 2 (each within the scatter of the next).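

In this assay, having no ring at this aromatic carbon does not set compound 4 apart from all the others: there is no change at the digits printed from compound 1 to compound 4 (within the scatter), even though benzyl has a ring and pentan-3-yl has none. The two other ring-bearing groups behave differently, with a 10-fold lower number from compound 3 to compound 4 (1.01 log units; beyond the scatter) and a 14-fold lower number from compound 2 to compound 4 (1.14 log units; beyond the scatter), so the compounds split into a low pair carrying benzyl or pentan-3-yl and a high pair carrying 4-(trifluoromethyl)phenyl or 4-fluorophenoxy, and the presence of a ring alone does not decide the number here. No measurement among these data accounts for this split.

On these data alone, it remains open where a plain phenyl, with neither a one-carbon link nor a substituent, would fall between these two pairs. As far as these compounds go, a longer chain such as heptyl, or a chain ending in an amine or a carboxylic acid, also remains open at this position.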